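Swapping a furan for a phenoxy group on the shared core

A few compounds are considered here, and "the series" means these few. Any claim that something is new, unique, unknown or untested is made for them only; others in the source may bear on it.

Of the compounds shown here, two built on one shared core have been measured in an assay on isolated protein for agonist activity at Bile acid receptor (Homo sapiens), read by AlphaScreen, with a stated time of 30 min; a higher number here means a larger maximal response, a lower number a smaller maximal response. Compound 1 `Cc1ccc(-n2nc(C)c3c2NC(=O)[C@H](C)S[C@@H]3c2ccc(Oc3ccccc3)cc2)cc1` gives 11% in this assay. Compound 2 `Cc1ccccc1-n1nc(C)c2c1NC(=O)[C@H](C)S[C@@H]2c1ccc(-c2ccco2)cc1` gives 32% in this assay, the higher of the two numbers; the gap to compound 1 lies beyond the usual scatter. Compound 3 `Cc1ccccc1-n1nc(C)c2c1NC(=O)[C@H](C)S[C@@H]2c1ccc(Oc2ccccc2)cc1` has not yet been measured. It differs from compound 2 in one place: phenoxy in place of furan-2-yl on an aromatic carbon. Within the data shown here, no direct step between measured compounds is available for this change, so the expectation rests on what the two values show. Compound 1, which also carries a phenoxy group, gives 11%, a low response. A downward step is therefore expected, estimated as a number 17 percentage points lower from compound 2 to compound 3 (beyond the scatter). Compound 3 is expected to give about 15% in this assay, with a likely range from 5% to 30%.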

Compound 3, largest response reached (reported as efficacy), in percent of the reference or control that the assay uses: 118%
Estimate against measurement, compound 3: 103 percentage points below; the whole stated range lies below it.
By their numbers in this assay, from the lowest: compound 1; then compound 2; then compound 3.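

In this assay, phenoxy in place of furan-2-yl on the aromatic carbon gives a number 86 percentage points higher from compound 2 to compound 3 (beyond the scatter), so phenoxy at this position can go with a large maximal response. The group on the aromatic nitrogen weighs heavily too: 2-methylphenyl in place of 4-methylphenyl gives a number 107 percentage points higher from compound 1 to compound 3 (beyond the scatter), which ties the low response of compound 1 to its 4-methylphenyl group rather than to phenoxy alone. Nothing available explains why either change moves the response so far.

Still open, from the compounds shown here alone, is how furan-2-yl would behave with 4-methylphenyl on the aromatic nitrogen, which would show whether the two changes act independently. Also open, going by these compounds, is whether a smaller phenyl group, an amine or a carboxylic acid on that aromatic carbon would keep the response.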